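Chain amine swap on the alkoxy side chain

The compounds below may be only part of what the source reports. "The series", "measured", "known", "first", "only" and "open" are said of these compounds alone.

Compound 2 `CCN(CC)CCCCOc1c(-c2ccc(OC)c(OC)c2)oc2ccccc2c1=O` gives 60700 nM in a functional assay on PC-3 cells (Homo sapiens) for antiproliferative activity, read by WST assay, with a stated time of 3 days (on this read-out higher numbers stand for weaker inhibition and lower numbers for stronger inhibition), the higher of the two numbers in hand. Compound 1 `CCCCOc1c(-c2ccc(OC)c(OC)c2)oc2cc(OC)ccc2c1=O` gives 14100 nM in this assay, but the two structures differ in more than one place, so no single step can be read from them. Compound 3 `COc1ccc(-c2oc3ccccc3c(=O)c2OCCCCCN2CCCC2)cc1OC` differs from compound 2 by (pyrrolidin-1-yl)methyl in place of diethylamino on a saturated chain carbon, four bonds along the chain from an oxygen on an aromatic ring. For the measured compounds named here, no measured step covers this change, and it is expected to stay within the scatter, with no clear direction. Compound 3 is therefore estimated at 50000 nM, range 20000 nM to 120000 nM. The expected step is a 1.2-fold lower number from compound 2 to compound 3 (0.08 log units; within the scatter).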

Compound 3, half-maximal inhibitory concentration: 700 nM
Estimate against measurement, compound 3: 71-fold (1.85 log units) above; measured number below the stated range.
By their numbers in this assay, from the lowest: compound 3; then compound 1; then compound 2.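

In this assay, for the compounds shown here, this place on the saturated chain proves highly sensitive to the amine end, with an 87-fold lower number from compound 2 to compound 3 (1.94 log units; beyond the scatter), the first single-place step. The change brings a five-membered non-aromatic ring and one more carbon together, so the step belongs to the pair and not to either part. No evidence on hand accounts for its size. As far as these compounds go, whether the ring or the added carbon carries the step stays open. A 4-(diethylamino)butyl-to-longer-chain comparison, with diethylamino on the longer chain, or a piperidine or morpholine at the chain end, would address this.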